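Swapping a methylphenyl for an azido-methoxyphenyl group

A few compounds are considered here, and "the series" means these few. Any claim that something is new, unique, unknown or untested is made for them only; others in the source may bear on it.

Measured so far:
compound 1 `COc1ccc(CN(C(=O)CSc2nc3ccccc3s2)c2cc(OC)c(OC)c(OC)c2)cc1C`: 6360 nM
compound 2 `COc1cc(N(Cc2ccc(C)cc2)C(=O)CSc2nc3ccccc3s2)cc(OC)c1OC`: 54200 nM

In a functional assay on MGC-803 cells (Homo sapiens) for antiproliferative activity, read by MTT assay, with a stated time of 48 h (a lower number here means a stronger inhibitor, a higher number a weaker inhibitor), compound 2 holds the higher of the two numbers, which makes it the weaker inhibitor of the pair. For the measured compounds named here, the only measured step is an 8.5-fold higher number from compound 1 to compound 2 (0.93 log units; beyond the scatter). It comes from 4-methylphenyl in place of 4-methoxy-3-methylphenyl.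

Compound 3 `COc1ccc(CN(C(=O)CSc2nc3ccccc3s2)c2cc(OC)c(OC)c(OC)c2)cc1N=[N+]=[N-]` differs from compound 2 in one place: 3-azido-4-methoxyphenyl in place of 4-methylphenyl on a saturated chain carbon bound to an amide-type nitrogen. In words, 3-azido-4-methoxyphenyl replaces 4-methylphenyl on a saturated chain carbon bound to an amide-type nitrogen. The new group carries a methoxy, as does the group in compound 1 at 6360 nM. Going by the values given here, a drop of about the size of that one step is therefore expected in this assay, though no azido compound has a measured value yet. The estimated step is an 8.3-fold lower number from compound 2 to compound 3 (0.92 log units; beyond the scatter). For compound 3 the expected value is 6500 nM, with an estimated range of 1800 nM to 25000 nM.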

Compound 3, half-maximal inhibitory concentration: 187 nM
Compound 3: middle estimate off by 35-fold (1.54 log units), on the high side, and the stated range ends above it.
By their numbers in this assay, from the lowest: compound 3; then compound 1; then compound 2.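

In this assay, the aromatic group on the saturated chain carbon bound to an amide-type nitrogen proves far more sensitive to change than the earlier step showed: 3-azido-4-methoxyphenyl in place of 4-methylphenyl gives a 290-fold lower number from compound 2 to compound 3 (2.46 log units; beyond the scatter). The methoxy cannot be the whole story, since with the methoxy kept, azido in place of methyl on an aromatic carbon still gives a 34-fold lower number from compound 1 to compound 3 (1.53 log units; beyond the scatter), so in this pair the azido alone separates a moderate inhibitor from a much stronger one. No measurement here explains why this swap has such a large effect.

On these data alone, it remains open whether the gain is particular to azido or would also appear with another group in its place, such as an amine or a nitrile. As far as these compounds go, it is also open whether azido would hold this level on a ring without the methoxy.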